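Moving the Fluorine Around the Phenyl Ring

This account rests on a few compounds, and the source may have more. Where it says the series, first, only, none or still open, it means among the compounds named here.

Compound 1 `Cc1ccc(-c2nc(C)c(COc3ccc4c(c3)OCC4CC(=O)O)s2)cc1`: 54.9% in a functional assay on CHO cells for agonist activity at Free fatty acid receptor 1 (Homo sapiens), read by FLIPR and calcium flux, tested at 100 nM; on this read-out lower numbers stand for a weaker effect and higher numbers for a stronger effect at the one concentration tested
Compound 2 `Cc1nc(-c2ccccc2F)sc1COc1ccc2c(c1)OCC2CC(=O)O`: 25.8%

Among the compounds with values here, compound 2 has the lowest of the two numbers; the one measured step, a number 29.1 percentage points lower from compound 1 to compound 2 (beyond the scatter), separates it from compound 1. Compound 3 `Cc1nc(-c2ccc(F)cc2)sc1COc1ccc2c(c1)OCC2CC(=O)O` differs from compound 2 by 4-fluorophenyl in place of 2-fluorophenyl on an aromatic carbon. Within the data shown here, no measured step moves a fluorine within the phenyl ring, so the only guidance is that compound 1, whose substituent sits at the 4-position, gives 54.9%. Compound 3 is therefore expected to rise by a number 14.2 percentage points higher from compound 2 to compound 3 (beyond the scatter), though this is uncertain. The estimate for compound 3 is 40%, between 20% and 65%.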

Compound 3, a percentage reported as activity, at one concentration (the size of the read-out at that concentration, not a potency): 61.6%
The estimate for compound 3 lay 21.6 percentage points below the measured number; the measured number falls inside the stated range.
By their numbers in this assay, from the lowest: compound 2; then compounds 1 and 3 (each within the scatter of the next).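

Moving the fluorine on the same phenyl ring gives a number 35.8 percentage points higher from compound 2 to compound 3 (beyond the scatter) in this assay and with no change in atoms, so where the fluorine sits matters, and 2-fluorophenyl is the poorer of these two placements. Changing 4-methylphenyl to 4-fluorophenyl gives a number 6.7 percentage points higher from compound 1 to compound 3 (within the scatter) and so separates neither group from the other. No measurement shown here explains the effect of moving the fluorine.

Still open, from the compounds shown here alone, is how 3-fluorophenyl would compare with these two placements. Also open, going by these compounds, is whether a larger group, as in 4-methoxyphenyl, would keep the same level of effect.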